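This account rests on a few compounds, and the source may have more. Where it says the series, first, only, none or still open, it means among the compounds named here.

Compound 1 `COc1ncc(-c2ccc3nc(NC(C)=O)nn3c2)cc1NS(=O)(=O)c1ccc(Cl)cc1` and compound 2 `COc1ncc(-c2ccc3nc(NC(C)=O)nn3c2)cc1NS(=O)(=O)c1ccc(C)cc1` share one core, while compound 3 `COc1ncc(-c2ccn3nc(NC(C)=O)nc3c2)cc1NS(=O)(=O)c1ccc(Cl)cc1` and compound 4 `COc1ncc(-c2ccn3nc(NC(C)=O)nc3c2)cc1NS(=O)(=O)c1ccc(C)cc1` are built on a second core; the difference between the two cores is not broken down here. In a functional assay on U-87MG ATCC cells (Homo sapiens) for antiproliferative activity, read by MTT assay, with a stated time of 48 h (on this read-out higher numbers stand for weaker inhibition and lower numbers for stronger inhibition), compound 1 gives 2090 nM, and compound 2 gives 1600 nM. In this assay compound 3 gives 2120 nM. The change from compound 1 to compound 2 is methyl in place of chloro on an aromatic carbon, and it made a 1.3-fold lower number from compound 1 to compound 2 (0.12 log units; within the scatter). Compound 4 carries the same change on the second core: methyl in place of chloro on an aromatic carbon. The step on the second core is expected to be a 1.3-fold lower number from compound 3 to compound 4 (0.11 log units; within the scatter), because the same change on the first core gave a 1.3-fold lower number from compound 1 to compound 2 (0.12 log units; within the scatter). Compound 4 is therefore estimated at 1650 nM in this assay, with a likely range from 900 nM to 3200 nM.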

Compound 4, half-maximal inhibitory concentration: 2030 nM
Estimate against measurement, compound 4: 1.2-fold (0.09 log units) below; low and high end bracket the measured number.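

In this assay, methyl in place of chloro on the second core gives a 1.0-fold lower number from compound 3 to compound 4 (0.02 log units; within the scatter) and so leaves the number essentially unchanged. Set beside the first core, the step shows no difference that stands out from the scatter: the same change on two cores in this assay, a 1.3-fold lower number (0.12 log units; within the scatter) from compound 1 to compound 2 and a 1.0-fold lower number (0.02 log units; within the scatter) from compound 3 to compound 4, 1.3-fold (0.10 log units) apart, within the scatter of two such steps.
This shows that the change behaved alike on these two cores, but as neither step lies beyond the scatter, it does not show that a step of real size would carry across, and one pair on each core sets no general rule.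

The compounds shown leave open whether an amine, a methoxy group or a carboxylic acid in place of the chloro would move the number on either core. They also leave open whether such a step would be the same on both.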